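Replacing 2-(methoxycarbonyl)ethenyl with 3-hydroxypropyl: notes on compound 4

The source may hold more compounds than are shown below. What is called first, only, known or untested is meant among the compounds shown, and "the series" means these compounds.

Measured so far in a functional assay on SW1573 cells (Homo sapiens) for antiproliferative activity, read by sulforhodamine B assay, with a stated time of 48 h (on this read-out higher numbers stand for weaker inhibition of growth and lower numbers for stronger inhibition of growth), for the series:
- Compound 1 `CC(C)(C)[Si](C)(C)O[C@@H]1CCCO[C@@H]1CO` gives > 100000 nM (a limit of the assay)
- Compound 2 `CC(C)(C)[Si](C)(C)O[C@@H]1CCCO[C@@H]1CO/C=C/C(=O)OCc1ccccc1` gives 26000 nM
- Compound 3 `COC(=O)/C=C/OC[C@H]1OCCC[C@H]1O[Si](C)(C)C(C)(C)C` gives 50000 nM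

Compound 3 at 50000 nM and compound 2 at 26000 nM lie within the scatter of each other in this assay and cannot be ordered. Compound 1 stands at > 100000 nM and that value is a limit of the assay, not a number.

The change to compound 4 `CC(C)(C)[Si](C)(C)O[C@@H]1CCCO[C@@H]1COCCCO` is 3-hydroxypropyl in place of 2-(methoxycarbonyl)ethenyl on an oxygen on a saturated carbon. Counted out, it reads 3-hydroxypropyl in place of 2-(methoxycarbonyl)ethenyl on an oxygen on a saturated carbon in full.

Going by the values given here, two measured steps bear on this change. The first is an at least 2.0-fold lower number from compound 1 to compound 3 (0.30 log units; that floor lies within the scatter) and it adds the group that compound 4 gives up, so a move back toward weaker inhibition is expected, though only weakly supported. The second is a 1.9-fold higher number from compound 2 to compound 3 (0.28 log units; within the scatter) and it leaves that group in place, so it sets no size here. Among the compounds with values here, no measured compound carries 3-hydroxypropyl.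

The step expected is a 1.6-fold higher number from compound 3 to compound 4 (0.20 log units; within the scatter) and it may not clear the scatter. A report only at the limit of > 100000 nM in this assay, at which 1 of the 3 values shown sits, is also expected to be possible for compound 4. The estimate for compound 4 is 80000 nM with an estimated range of 35000 nM to 130000 nM in this read-out.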

Compound 4, concentration for 50% growth inhibition: > 100000 nM
Compound 4: only a limit was reported; the forecaster's own chance of this, stated with the estimate: 40%; at least 1.2-fold (0.09 log units) between middle value and limit.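

In this assay compound 4 gives > 100000 nM, which is a limit of the assay and not a number. On an oxygen on a saturated carbon, 3-hydroxypropyl in place of 2-(methoxycarbonyl)ethenyl gives an at least 2.0-fold higher number from compound 3 to compound 4 (0.30 log units; that floor lies within the scatter), so the change has a floor but no fixed size, and that floor does not clear the scatter. The step from compound 1 to compound 4 cannot be read, so 3-hydroxypropyl is not separated from the hydrogen of compound 1, and among the four compounds only compound 2 and compound 3, which carry an ester-bearing ethenyl group on this oxygen, give numbers rather than the shared ceiling: the limit of > 100000 nM in this assay, at which 2 of the 4 values shown sit.

The compounds shown leave open which part of the change matters, as the double bond, the ester carbonyl and the terminal hydroxyl all differ together between compound 3 and compound 4. A saturated propyl chain ending in a methyl ester, or a chain ending in a carboxylic acid or an amine, would begin to separate these features and show whether this position can give a readable number without the ethenyl group.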